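This account rests on a few compounds, and the source may have more. Where it says the series, first, only, none or still open, it means among the compounds named here.

Values so far in an ADME assay on the whole organism (Canis lupus familiaris, strain Beagle) for pharmacokinetics; a lower number here means that a smaller share of the oral dose reaches the circulation, a higher number that a larger share of the oral dose reaches the circulation

Compound 1 `CCn1c(-c2cnc(C)nc2)nc2c(N[C@H]3CCN(C(=O)N4CC(OC)C4)C3)ncnc21` gives 69%
Compound 2 `CCn1c(-c2ccc(C(F)(F)F)nc2)nc2c(O[C@H]3CCN(C(=O)C4CCOC4)C3)ncnc21` gives 100%
Compound 3 `CCn1c(-c2cnc(C)nc2)nc2c(N[C@H]3CCN(C(=O)[C@H]4C[C@@H](OC)C4)C3)ncnc21` gives 85%

Compound 3 at 85% is second highest of the three numbers, with compound 2 at 100% over it and compound 1 at 69% under it, both gaps beyond the scatter.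

Compound 4 `CCn1c(-c2cnc(C)nc2)nc2c(N[C@H]3CCN(C(=O)C4CC4)C3)ncnc21` has not yet been measured. It carries cyclopropyl in place of 3-methoxycyclobutyl on a carbonyl carbon, and the counted difference is cyclopropyl in place of 3-methoxycyclobutyl on a carbonyl carbon at that one place.

For the measured compounds named here, only one measured step bears on this place. It is a number 16 percentage points higher from compound 1 to compound 3 (beyond the scatter) and replaces one group on the carbonyl carbon with another, a modest change beyond the scatter. Going by the values given here, that step shows the number can respond to the group at this place, but no measured compound carries cyclopropyl, so its direction does not carry over. A change of similar size or smaller is therefore expected, most likely within the scatter, with a slight lean downward. The expected step is a number 7 percentage points lower from compound 3 to compound 4 (within the scatter) in this assay on this reasoning. Compound 4 is estimated at 78% with 55% to 98% as the expected range.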

Compound 4, oral bioavailability: 95%
Compound 4: middle estimate off by 17 percentage points, on the low side; low and high end bracket the measured number.
By their numbers in this assay, from the lowest: compound 1; then compounds 3, 4 and 2 (each within the scatter of the next, the first and the last beyond it).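

In this assay, the step of a number 10 percentage points higher from compound 3 to compound 4 (within the scatter) means that cyclopropyl and 3-methoxycyclobutyl are not told apart on a carbonyl carbon whose other neighbour is an amide-type nitrogen in a ring, even though the hydrogen-bond acceptor and the 2 defined stereocentres leave with the 3-methoxycyclobutyl. The second reading, a number 26 percentage points higher from compound 1 to compound 4 (beyond the scatter), joins a number 16 percentage points higher from compound 1 to compound 3 (beyond the scatter) and sets 3-methoxyazetidin-1-yl apart from both carbocyclic groups, so among compound 1, compound 3 and compound 4 the number at this place follows the azetidinyl group rather than the size of the group or the presence of the methoxy oxygen. No measured data at hand account for either step.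

Still open, from the compounds shown here alone, is how far this holds for quite different groups on the same carbonyl carbon, such as an aminomethyl group, a carboxylic acid or a longer alkyl chain. Also open, going by these compounds, is whether the exchange of 3-methoxycyclobutyl for cyclopropyl reads the same on the core of compound 2, which differs from the others in more than one place.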